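Fluoro Added to the Lowest Compound of Three

A few compounds are considered here, and "the series" means these few. Any claim that something is new, unique, unknown or untested is made for them only; others in the source may bear on it.

Compound 1, `COc1ccc(-c2csc3nc(-c4cc(F)c(Cl)cc4Cl)nn23)cc1`, gives 40.6%; compound 2, `Fc1cc(-c2nc3scc(-c4ccc(Cl)cc4)n3n2)c(Cl)cc1Cl`, gives 42.2%; compound 3, `Fc1cc(-c2nc3scc(-c4ccc(Cl)cc4Cl)n3n2)c(Cl)cc1Cl`, gives 17.2%.

These values come from a functional assay on the whole organism (strain Wister albino) for inhibition, with Rattus norvegicus as the target, read by paw edema, with stated times of 30 min and 3 h, at a dose of 50 mg/kg by the oral route; on this read-out higher numbers stand for more inhibition at the one dose given (going by the name of the read-out) and lower numbers for less inhibition. Compound 3 stands lowest of the three, with compound 1 nearest and compound 2 furthest, both beyond the scatter. Compound 4, `Fc1cc(-c2nc3scc(-c4cc(F)c(Cl)cc4Cl)n3n2)c(Cl)cc1Cl`, differs from compound 3 only by fluoro in place of hydrogen on an aromatic carbon. Within the data shown here, no measured step adds a fluoro group, so the closest guide is a number 25 percentage points lower from compound 2 to compound 3 (beyond the scatter), while a number 1.6 percentage points higher from compound 1 to compound 2 (within the scatter) shows a halogen swap leaving the number unchanged. Another halogen on an already low compound is therefore expected to give little change beyond the scatter, so compound 4 is estimated at 18%, between 6% and 32%, a step of a number 0.8 percentage points higher from compound 3 to compound 4 (within the scatter).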

Compound 4, a percentage reported as inhibition, in the whole organism at one dose (the size of the read-out at that dose, not a potency): 59.4%
Beside the measured number, compound 4's estimate is 41.4 percentage points below it, outside the stated range (above it).
By their numbers in this assay, from the lowest: compound 3; then compounds 1 and 2 (each within the scatter of the next); then compound 4.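

On the ring that already carries the chloro groups, one added halogen can move the number either way: chloro gave a number 25 percentage points lower from compound 2 to compound 3 (beyond the scatter), whereas fluoro, ortho to one chloro group and para to another, gave a number 42.2 percentage points higher from compound 3 to compound 4 (beyond the scatter). So a single fluorine atom at this position is enough to produce a large change. Nothing measured here says why. On these data alone, whether a nitrile or an amine at this same position would also raise the number stays open, as does whether fluoro would act the same way without the neighbouring chloro groups.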